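Swapping (pyridin-2-yl)methyl for (3-hydroxypyrrolidin-1-yl)carbonyl

The source may report more compounds than this note shows. Statements on the series, on what has been measured and on what is new or still open speak of the compounds shown alone.

Measured so far in an ADME assay on microsomes from liver (Mus musculus) for metabolic stability, read by mass spectrometry, with a stated time of 40 min, tested at 1 uM; a higher number here means that more of the compound is left, a lower number that less of the compound is left
- compound 1 `COc1cc(N2CCN(C(=O)N3CCN(C)CC3)CC2)ccc1Nc1nc(NC2CCCCC2)c2nc[nH]c2n1` with 46%
- compound 2 `COc1cc(N2CCN(Cc3ccccn3)CC2)ccc1Nc1nc(NC2CCCCC2)c2nc[nH]c2n1` with 38%

On these two numbers, compound 2 stands within the usual scatter of compound 1, so neither can be ranked over the other in this assay at this stage. The next structure is compound 3 `COc1cc(N2CCN(C(=O)N3CCC(O)C3)CC2)ccc1Nc1nc(NC2CCCCC2)c2nc[nH]c2n1`, which differs from compound 2 by one exchange ((3-hydroxypyrrolidin-1-yl)carbonyl in place of (pyridin-2-yl)methyl on an amine nitrogen in a ring). Here (3-hydroxypyrrolidin-1-yl)carbonyl stands in place of (pyridin-2-yl)methyl on an amine nitrogen in a ring. Among the compounds with values here, one measured step bears on this change, at the same nitrogen: a number 8 percentage points lower from compound 1 to compound 2 (within the scatter) with (pyridin-2-yl)methyl in place of (4-methylpiperazin-1-yl)carbonyl. Within the data shown here, no measured compound carries the 3-hydroxypyrrolidin-1-yl group, so that step is the only guide. Compound 3 shares a carbonyl on that nitrogen with compound 1, which gives 46% here. No step beyond the scatter is therefore expected, only a slight upward drift at most. The estimate is a number 7 percentage points higher from compound 2 to compound 3 (within the scatter) as the expected move. Compound 3 is expected at 45% with 28% to 62% as the estimated range.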

Compound 3, percent of the compound remaining: 47%
Beside the measured number, compound 3's estimate is 2 percentage points below it; the measured number falls inside the stated range.
By their numbers in this assay, from the lowest: compounds 2, 1 and 3 (each within the scatter of the next).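

Within the data shown here, the exchange of 4-methylpiperazin-1-yl for 3-hydroxypyrrolidin-1-yl on the carbonyl carbon gives the only measured change within the carbonyl-bearing group, and in this assay it comes to a number 1 percentage points higher from compound 1 to compound 3 (within the scatter), so the two rings on that carbonyl cannot be told apart in this read-out. Placing (3-hydroxypyrrolidin-1-yl)carbonyl in place of (pyridin-2-yl)methyl on the amine nitrogen in a ring gives a number 9 percentage points higher from compound 2 to compound 3 (within the scatter), which adds a second carbonyl-linked group to the comparison with the (pyridin-2-yl)methyl compound. Across the three compounds, this nitrogen has therefore carried two carbonyl-linked groups and one (pyridin-2-yl)methyl group, and no step among those printed lies beyond the scatter.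

From the compounds shown here alone, it remains open whether any group at this position can move the percent of compound remaining beyond the scatter, for instance a plain pyrrolidin-1-yl or a morpholin-4-yl on the carbonyl carbon, or an acetyl on the nitrogen itself. Why the numbers lie as they do also stays open, as nothing at hand speaks to a cause.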